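A few compounds are considered here, and "the series" means these few. Any claim that something is new, unique, unknown or untested is made for them only; others in the source may bear on it.

Working notes on the series in an assay on HEK293 cells for positive allosteric modulation of metabotropic glutamate receptor 3 (Rattus norvegicus), read by thallium flux, with a stated time of 2.5 min; on this read-out higher numbers stand for larger maximal responses and lower numbers for smaller maximal responses.

Compound 1 `Cc1c(OCCCCOc2ccc(C(=O)O)cc2)ccc(C(=O)CC2CCCC2)c1O` gives 26.7% in this assay. Compound 2 `Cc1c(OCCCCOCOc2ccc(C(=O)O)cc2)ccc(C(=O)CC2CCCC2)c1O` gives 46.9%, and the gap is a number 20.2 percentage points higher from compound 1 to compound 2 (beyond the scatter). Compound 3 `Cc1c(OCCCCOc2cccc(C(=O)O)c2)ccc(C(=O)CC2CCCC2)c1O` gives 92.9%, the highest of the three numbers; the nearest is compound 2, separated by a number 46 percentage points higher from compound 2 to compound 3 (beyond the scatter), and the furthest is compound 1, separated by a number 66.2 percentage points higher from compound 1 to compound 3 (beyond the scatter). Both steps that lead to compound 3 concern the aryl carboxylic acid end of the chain, and both are beyond the scatter.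

Compound 4 `Cc1ccc(C(=O)O)cc1OCCCCOc1ccc(C(=O)CC2CCCC2)c(O)c1C` awaits measurement. It differs from compound 3 by methyl in place of hydrogen on an aromatic carbon. Within the data shown here, no measured step exchanges a hydrogen for a methyl on this aromatic ring: the steps from compound 1 to compound 2 and from compound 1 to compound 3 move the carboxy group or lengthen the linker, and neither maps onto the present change. They show only that the read-out is sensitive to alterations at this end of the molecule, which argues for some caution, but they give no direction for a single methyl. The expected step of a number 7.9 percentage points lower from compound 3 to compound 4 (within the scatter) is therefore within the scatter. Compound 4 is estimated at 85%, with a range from 60% to 100%.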

Compound 4, largest response reached (reported as percent of maximum), in percent of the reference or control that the assay uses: 26.9%
Compound 4: middle estimate off by 58.1 percentage points, on the high side, outside the stated range (below it).
By their numbers in this assay, from the lowest: compounds 1 and 4 (each within the scatter of the next); then compound 2; then compound 3.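

In this assay, one methyl on the aromatic carbon ortho to a large group and para to a carboxy group removes the advantage held by the 3-carboxyphenyl end (a number 66 percentage points lower from compound 3 to compound 4 (beyond the scatter)), so this carbon, unlike what the carboxy shift alone suggested, is a sharply sensitive point where the smallest carbon substituent matters as much as relocating the acid. Measured against the other two ends, the 5-carboxy-2-methylphenyl end gives a modest step down (a number 20 percentage points lower from compound 2 to compound 4 (beyond the scatter)) and no separation from the 4-carboxyphenyl end (a number 0.2 percentage points higher from compound 1 to compound 4 (within the scatter)), which places compound 4 with compound 1 and well away from compound 3. Nothing available bears on why a single methyl has an effect of this size.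

From the compounds shown here alone, it remains open whether the loss is specific to methyl or follows from any substituent on this carbon, a question that a fluorine, a chlorine or a methoxy at the same place would address. Also open, going by these compounds, is whether a methyl on the remaining carbons of this ring gives the same result, or whether the loss is confined to this one position.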